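From Methylamino to Ethylamino: Compound 3 to Compound 4

The source may hold more compounds than are shown below. What is called first, only, known or untested is meant among the compounds shown, and "the series" means these compounds.

Compound 1, `OC[C@H]1O[C@@H](n2cnc3c(NCc4ccccc4)nccc32)C[C@@H]1O`, gives 8% in a functional assay on EL4 cells (Mus musculus) for inhibition, tested at 100 uM; a higher number here means more inhibition at the concentration tested (going by the name of the read-out), a lower number less inhibition.
Compound 2, `[O-][n+]1ccc2c(c1)ncn2C1O[C@H](CO)[C@@H](O)[C@H]1O`, sits at the limit of < 5% in this assay, a limit and not a number.
Compound 3, `CNc1[nH]ccc2ncnc1-2`, likewise sits at the limit of < 5% in this assay, again a limit rather than a number.

Compound 3 therefore stands at the floor of what this assay reports, and it is not alone there: the limit of < 5% in this assay, at which 2 of the 3 values shown sit. Only compound 1 returns a number at all, and that number is small. Within the data shown here, no pair of measured compounds differs in a single place, so no measured step is available for guidance.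

Compound 4, `CCNc1[nH]ccc2ncnc1-2`, differs from compound 3 by methyl in place of hydrogen on a saturated chain carbon bound to a nitrogen on an aromatic ring. Given that compound 3 rests at the limit < 5%, this small lengthening of the chain is expected to yield no step beyond the scatter in this assay. Compound 4 is thus estimated at about 4%, within a range from 0% to 12%, and most probably reported only as a limit again. The expected step that the limit leaves unreadable from compound 3 to compound 4 lies within the scatter.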

Compound 4, a percentage reported as inhibition, at one concentration (the size of the read-out at that concentration, not a potency): < 5%
Compound 4 gave a limit, no number; the forecaster's own chance of this, stated with the estimate: 70%; the middle value does not contradict the limit.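

No step can be read from compound 3 to compound 4, as each gives only a limit in this assay: the limit of < 5% in this assay, at which 3 of the 4 values shown sit.

The compounds shown leave open whether going from methylamino to ethylamino changes inhibition at all in this assay.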